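A few compounds are considered here, and "the series" means these few. Any claim that something is new, unique, unknown or untested is made for them only; others in the source may bear on it.

Of the compounds shown here, two have numbers so far. Compound 1 `CCCc1nc2ccccc2c(=O)n1/N=C/c1ccc(Oc2ccc(Cl)cc2)cc1` gives 5.78 in a physicochemical assay for lipophilicity, in phosphate buffer, measured as octanol-water partition; on this read-out lower numbers stand for lower lipophilicity and higher numbers for higher lipophilicity. Compound 2 `O=c1c2ccccc2nc(-c2ccccc2)n1/N=C/c1ccc(Oc2ccc(F)cc2)cc1` gives 6.21 in this assay, the higher of the two numbers, and its gap to compound 1 lies beyond the scatter. Compound 3 `O=c1c2ccccc2nc(-c2ccccc2)n1/N=C/c1ccc(Oc2ccc(Cl)cc2)cc1` has not yet been measured. Its difference from compound 2 is chloro in place of fluoro on an aromatic carbon. Among the measured compounds shown here, no measured step covers this change in this assay, so the expectation rests on the change alone: a modest upward step, beyond the scatter, expected as a number 0.49 log units higher from compound 2 to compound 3 (beyond the scatter). Compound 3 is expected to give 6.7 in this assay, with a range from 6.3 to 7.1.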

Compound 3, partition coefficient: 6.38
Compound 3: the middle estimate sits 0.32 log units above what was measured; the measured number falls inside the stated range.
By their numbers in this assay, from the lowest: compound 1; then compounds 2 and 3 (each within the scatter of the next).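

In this assay chloro in place of fluoro on the aromatic carbon gives a number 0.17 log units higher from compound 2 to compound 3 (within the scatter), so on this core the read-out does not separate the two halogens. With the 4-chlorophenoxy part held constant, phenyl in place of propyl gives a number 0.60 log units higher from compound 1 to compound 3 (beyond the scatter), a step that can be assigned to that single change. Nothing at hand accounts for either step.

Still open, from the compounds shown here alone, is whether the phenyl for propyl step holds with fluoro in place of chloro. Also open, going by these compounds, is how an amine or a carboxylic acid in place of chloro, or a longer chain in place of propyl, would read in this assay.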